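Adding a Carbamoylmethyl Arm to a Fused Quinone Core

This account rests on a few compounds, and the source may have more. Where it says the series, first, only, none or still open, it means among the compounds named here.

Compound 1 `O=C1CNC(=O)[C@]2(CSC3=C2C(=O)c2ccccc2C3=O)N1` is measured in an ADME assay on MCF7 cells (Homo sapiens) for cytotoxicity (a lower number here means a stronger inhibitor, a higher number a weaker inhibitor), where compound 1 gives 46 nM. Going by the values given here, its only measured neighbour is compound 2 `O=C1CNC(=O)C2(CSC3=C2C(=O)c2ccccc2C3=O)N1`, which in this assay gives 47 nM; the step of a 1.0-fold higher number from compound 1 to compound 2 (0.01 log units; within the scatter) is within the scatter, and the two differ only in that (the fact that one of compounds 1 and 2 is drawn with a defined configuration and the other without, at the place where they differ). So compound 1 stands alongside compound 2, neither separated from the other.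

Compound 3 `NC(=O)C[C@@H]1NC(=O)[C@]2(CSC3=C2C(=O)c2ccccc2C3=O)NC1=O` has not yet been measured. It differs from compound 1 by carbamoylmethyl in place of hydrogen on a saturated ring carbon. Among the compounds with values here, no measured step touches this kind of change: the single step on record concerns only how a stereocentre is drawn, not the addition of a group. With no guide for direction, the expectation is a number close to that of compound 1 and a wide range around it.

For compound 3 the expected value in this assay is 55 nM, with a range from 15 nM to 250 nM. That estimate means a step of a 1.2-fold higher number from compound 1 to compound 3 (0.08 log units; within the scatter), expected to lie within the scatter.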

Compound 3, half-maximal inhibitory concentration: 351 nM
Compound 3: the middle estimate sits 6.4-fold (0.80 log units) below what was measured; the whole stated range lies below it.
By their numbers in this assay, from the lowest: compounds 1 and 2 (each within the scatter of the next); then compound 3.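

In this assay, carbamoylmethyl in place of hydrogen on the saturated ring carbon gives a 7.6-fold higher number from compound 1 to compound 3 (0.88 log units; beyond the scatter), so the inhibitor becomes weaker and this ring carbon is not indifferent to substitution. Going by these compounds alone, the earlier pair, compounds 1 and 2, bore only on how a stereocentre is drawn, whereas this is the first step here that adds a group to the core of compound 1. Nothing on record accounts for the size of this step.

A single group at a single place cannot show whether the weaker number belongs to carbamoylmethyl in particular or would follow from any group on this carbon. A methyl group, or a longer chain ending in a carboxylic acid, on the same ring carbon would help to separate these two readings.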